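Shortening the Amino Chain on a Thiadiazole Amine Oxidase Inhibitor

This account rests on a few compounds, and the source may have more. Where it says the series, first, only, none or still open, it means among the compounds named here.

Measured compounds:
compound 1, `CCCNc1nnc(SCC(=O)N(Cc2cccc([N+](=O)[O-])c2)c2ccc(F)cc2)s1`, 241 nM
compound 2, `CC(C)CNc1nnc(SCC(=O)N(Cc2cccc([N+](=O)[O-])c2)c2ccc(F)cc2)s1`, 1790 nM
compound 3, `C=CCNc1nnc(SCC(=O)N(Cc2cccc([N+](=O)[O-])c2)c2ccc(F)cc2)s1`, 502 nM

The three compounds share one core and differ only in the small chain on the nitrogen attached to the aromatic ring. In an assay on isolated protein for inhibition of Amine oxidase [flavin-containing] A (Homo sapiens), read by fluorescence and Amplex Red, with a stated time of 30 min (a higher number here means a weaker inhibitor, a lower number a stronger inhibitor), compound 1 gives 241 nM, compound 2 gives 1790 nM and compound 3 gives 502 nM. Compound 3 therefore stands in the middle: it sits a 2.1-fold higher number from compound 1 to compound 3 (0.32 log units; beyond the scatter), and on the other side there is a 3.6-fold lower number from compound 2 to compound 3 (0.55 log units; beyond the scatter).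

Compound 4, `CCNc1nnc(SCC(=O)N(Cc2cccc([N+](=O)[O-])c2)c2ccc(F)cc2)s1`, is not yet measured. It differs from compound 3 by methyl in place of vinyl on a saturated chain carbon bound to a nitrogen on an aromatic ring, so the chain becomes shorter by one carbon and loses its double bond.

Among the measured compounds shown here, two measured steps bear on this. The step of a 2.1-fold higher number from compound 1 to compound 3 (0.32 log units; beyond the scatter) shows that swapping vinyl for ethyl on this chain carbon moves the number only modestly. The step of a 7.4-fold higher number from compound 1 to compound 2 (0.87 log units; beyond the scatter) shows that adding a methyl to the chain costs more. Compound 4 removes atoms rather than adding them, so the expected step is small, leaning toward a lower number than compound 3 but staying within the spread seen so far.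

Compound 4 is therefore expected to give 350 nM in this assay , with a range of 120 nM to 1000 nM, which means an expected step of a 1.4-fold lower number from compound 3 to compound 4 (0.16 log units; within the scatter).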

Compound 4, half-maximal inhibitory concentration: 336 nM
For compound 4 the middle estimate is 1.0-fold (0.02 log units) above the measured one; the range from low to high includes it.
By their numbers in this assay, from the lowest: compounds 1, 4 and 3 (each within the scatter of the next, the first and the last beyond it); then compound 2.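

The ethylamino chain of compound 4 cannot be told apart from either of its two unbranched neighbours: the allylamino chain, with its double bond, gives a 1.5-fold lower number from compound 3 to compound 4 (0.17 log units; within the scatter), and the longer chain of compound 1 gives a 1.4-fold higher number from compound 1 to compound 4 (0.14 log units; within the scatter). Neither removing that double bond nor trimming the chain by one carbon therefore makes a difference these measurements can resolve at this position, even though compound 1 and compound 3 lie beyond the scatter of each other, with compound 4 falling within the scatter of both. The branched chain remains the clear outlier, as replacing its isopropyl end with methyl gives a 5.3-fold lower number from compound 2 to compound 4 (0.73 log units; beyond the scatter), so among these four compounds only compound 2 stands well apart from the rest.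

As far as these compounds go, how a single methyl on that nitrogen, a bare amine with no chain, a longer butyl chain or a small cyclopropyl ring would compare remains open, so the shortest and longest chains this position accepts are still unknown. Nothing measured here explains why the branched chain stands apart.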